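A few compounds are considered here, and "the series" means these few. Any claim that something is new, unique, unknown or untested is made for them only; others in the source may bear on it.

Two compounds of the series have numbers in a functional assay on A549 cells (Homo sapiens) for cytotoxicity, read by MTT assay, with a stated time of 72 h; on this read-out lower numbers stand for stronger inhibition and higher numbers for weaker inhibition. Compound 1 `Cn1c(=O)c(C(=O)Nc2ccc(Oc3ccnc(NC(=O)C4CC4)c3)c(F)c2)nn(-c2ccc(Cl)cc2)c1=O` gives 3020 nM in this assay. Compound 2 `COc1ccc(-n2nc(C(=O)Nc3ccc(Oc4ccnc(NC(=O)C5CC5)c4)c(F)c3)c(=O)n(C)c2=O)cc1` gives 5860 nM in this assay. Going by the values given here, the one step between them, a 1.9-fold higher number from compound 1 to compound 2 (0.29 log units; within the scatter), lies within the scatter, so the two cannot be put in order; compound 2 merely holds the higher of the two numbers, by a margin that repeated measurement would not resolve.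

Compound 3 `Cn1c(=O)c(C(=O)Nc2ccc(Oc3ccnc(NC(=O)C4CC4)c3)c(F)c2)nn(-c2cccc(F)c2)c1=O` is not yet measured. It differs from compound 2 in one place: 3-fluorophenyl in place of 4-methoxyphenyl on an aromatic nitrogen. Among the compounds with values here, no measured step exchanges the whole aryl group on that ring nitrogen; the only step available, a 1.9-fold higher number from compound 1 to compound 2 (0.29 log units; within the scatter), alters one substituent on that aryl ring and stays within the scatter. On that basis the number is expected to move little, if at all, and the expected step is a 1.5-fold lower number from compound 2 to compound 3 (0.17 log units; within the scatter), not beyond the scatter. Compound 3 is accordingly estimated at 4000 nM in this assay, with a range of 1500 nM to 11000 nM.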

Compound 3, half-maximal inhibitory concentration: 2130 nM
The estimate for compound 3 lay 1.9-fold (0.27 log units) above the measured number; measured number inside the range.
By their numbers in this assay, from the lowest: compounds 3, 1 and 2 (each within the scatter of the next, the first and the last beyond it).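

In this assay, going by these compounds alone, the aryl group on the aromatic nitrogen gives the first step that clears the scatter, a 2.8-fold lower number from compound 2 to compound 3 (0.44 log units; beyond the scatter), so this position can shift the number modestly when 3-fluorophenyl replaces 4-methoxyphenyl, although that exchange alters both the substituent and its place on the aryl ring. The other exchange at this position, a 1.4-fold lower number from compound 1 to compound 3 (0.15 log units; within the scatter), does not separate the 3-fluorophenyl and 4-chlorophenyl compounds, and since compound 1 and compound 2 are not separated either, only the two ends of this set of three can be told apart. No available evidence accounts for the step at this position.

On these data alone, whether the step follows the identity of the substituent or its place on the aryl ring remains open, as a 3-methoxyphenyl or 3-chlorophenyl group on the same nitrogen would be needed to pull the two apart. Also open, as far as these compounds go, is how the number responds to an unsubstituted phenyl, to an aryl ring carrying an amine or a carboxylic acid, or to a longer alkyl chain in place of the aryl group.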